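Tolyl for Fluorophenyl on the Triazole Nitrogen

A few compounds are considered here, and "the series" means these few. Any claim that something is new, unique, unknown or untested is made for them only; others in the source may bear on it.

This account follows a dithiocarbamate series built on a shared core, tested in a functional assay on PC-3 cells (Homo sapiens) for inhibition, read by MTT assay, with a stated time of 72 h; on this read-out lower numbers stand for stronger inhibition and higher numbers for weaker inhibition. Compound 1 `CC(C)(C)OC(=O)N1CCN(C(=S)SCc2cn(-c3ccccc3F)nn2)CC1` carries a 2-fluorophenyl group on the triazole nitrogen. In this assay compound 1 gives only a limit, > 128000 nM, and no number. Compound 2 `CC(C)(C)OC(=O)N1CCN(C(=S)SCc2cn(Cc3cc(=O)oc4cc(O)ccc34)nn2)CC1` bears a coumarin-containing substituent and in this assay reaches 36800 nM. Compound 3 `Cc1ccc(Cn2cc(CSC(=S)N3CCN(C(=O)OCc4ccccc4)CC3)nn2)cc1`, with a 4-methylbenzyl group and a benzyl carbamate, gives in this assay only a limit, > 128000 nM. Thus two of the three values shown sit at the limit of > 128000 nM in this assay, at which 2 of the 3 values shown sit, and compound 1 stands among them, so no number places it against compound 2.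

Compound 4 `Cc1ccc(-n2cc(CSC(=S)N3CCN(C(=O)OC(C)(C)C)CC3)nn2)cc1` differs from compound 1 by 4-methylphenyl in place of 2-fluorophenyl on an aromatic nitrogen. Among the compounds with values here, no measured pair differs in a single place, so the size of this step is not known from the data. Since compound 1 shows only a limit, > 128000 nM, and compound 3, which also carries a methyl-substituted aryl on that nitrogen, shows only a limit, > 128000 nM, the expectation is that the step from compound 1 to compound 4, a step that the limit leaves unreadable from compound 1 to compound 4, stays within the scatter and that compound 4 again gives no number. Compound 4 is therefore estimated at 150000 nM, with a range from 40000 nM to 600000 nM.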

Compound 4, half-maximal inhibitory concentration: > 128000 nM
Compound 4 gave a limit, no number (the forecaster's own chance of this, stated with the estimate: 75%); the middle value is on the limit's open side.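

In this assay compound 4 gives only a limit, > 128000 nM. Within the data shown here, compound 1 also gives only a limit, so no step between compound 1 and compound 4 can be read. The compounds shown leave open whether 4-methylphenyl in place of 2-fluorophenyl on an aromatic nitrogen alters inhibition at all, and most values remain limits: the limit of > 128000 nM in this assay, at which 3 of the 4 values shown sit.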